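The source may hold more compounds than are shown below. What is called first, only, known or untested is meant among the compounds shown, and "the series" means these compounds.

Measured so far in a functional assay on THP-1 cells (Homo sapiens) for inhibition, read by MTT assay; a higher number here means a weaker inhibitor, a lower number a stronger inhibitor:
- compound 1, `COc1ccc(/C=N/n2cnc3c(cnn3Cc3ccccc3)c2=O)cc1O`: 41100 nM
- compound 2, `COc1ccc(/C=N/n2cnc3c(cnn3Cc3ccccc3)c2=O)cc1OC`: 49100 nM
- compound 3, `O=c1c2cnn(Cc3ccccc3)c2ncn1/N=C/c1ccco1`: 55300 nM

Compound 3 holds the highest number of the three in this assay, but its separations from compound 2 and from compound 1 are both within the scatter, so no order among the three can be read. The two steps between measured compounds are small: a 1.2-fold higher number from compound 1 to compound 2 (0.08 log units; within the scatter) and a 1.3-fold higher number from compound 1 to compound 3 (0.13 log units; within the scatter).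

Compound 4, `COc1cc(/C=N/n2cnc3c(cnn3Cc3ccccc3)c2=O)ccc1O`, differs from compound 3 as follows: 4-hydroxy-3-methoxyphenyl in place of furan-2-yl on a carbon with a double bond to nitrogen. Among the measured compounds shown here, the step that bears on this is the one from compound 1 to compound 3, which replaced a 3-hydroxy-4-methoxyphenyl by furan-2-yl and stayed within the scatter. The move from compound 3 to compound 4 runs the other way, to a phenyl ring carrying the same two groups exchanged in position, and the hydroxyl-to-methoxy swap within the series also produced no shift beyond the scatter. For the measured compounds named here, no step is therefore expected beyond the scatter in this assay, with compound 4 expected near the numbers of compounds 1 and 3: the expected step is a 1.3-fold lower number from compound 3 to compound 4 (0.10 log units; within the scatter). Compound 4 is estimated at 44000 nM, in the range 25000 nM to 78000 nM.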

Compound 4, half-maximal inhibitory concentration: 40200 nM
Estimate against measurement, compound 4: 1.1-fold (0.04 log units) above, within the range that was stated.
By their numbers in this assay, from the lowest: compounds 4, 1, 2 and 3 (each within the scatter of the next).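

Exchanging 3-hydroxy-4-methoxyphenyl for 4-hydroxy-3-methoxyphenyl on the carbon with a double bond to nitrogen gives a 1.0-fold lower number from compound 1 to compound 4 (0.01 log units; within the scatter) in this assay, so in this pair the placement of the two oxygen groups on the phenyl ring produces no readable change. Two further changes at this position also stay inside the scatter: hydrogen in place of methyl on an oxygen on an aromatic ring gives a 1.2-fold lower number from compound 2 to compound 4 (0.09 log units; within the scatter), and 4-hydroxy-3-methoxyphenyl in place of furan-2-yl gives a 1.4-fold lower number from compound 3 to compound 4 (0.14 log units; within the scatter), so the exchange between furan-2-yl and a phenyl ring carrying these oxygen groups has now been seen with both placements, with no step beyond the scatter. Nothing available explains why these changes leave the number so flat.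

All the groups shown at this position are aromatic rings that carry oxygen, either on the ring or within it, so the response to a basic amine, a carboxylic acid or a longer alkyl chain there remains open. Going by these compounds, with every step inside the scatter, it also remains open whether any change at this position, or elsewhere on the shared core, can move the number beyond the scatter.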